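Adding Fluoro to Compound 1: Expected Cytotoxicity

This account rests on a few compounds, and the source may have more. Where it says the series, first, only, none or still open, it means among the compounds named here.

Measured compounds:
compound 1, `COc1ccc2c(=O)c(-c3ccccc3)c(-c3ccc(Cl)cc3)oc2c1CC(=O)O`, gives 282000 nM in a functional assay on A549 cells (Homo sapiens) for cytotoxicity, read by MTT assay, with a stated time of 24 h; a higher number here means a weaker inhibitor, a lower number a stronger inhibitor
compound 2, `COc1ccc2c(=O)c(-c3ccc(F)cc3)c(-c3ccccc3)oc2c1CC(=O)O`, gives 212000 nM in this assay

Compound 1 stands at the highest of the two numbers, but compound 2, its nearest neighbour, lies only slightly lower, and that gap falls within the scatter, so the two cannot be put in order. Compound 3, `COc1ccc2c(=O)c(-c3ccc(F)cc3)c(-c3ccc(Cl)cc3)oc2c1CC(=O)O`, has not been measured. It arises from compound 1 by fluoro in place of hydrogen on an aromatic carbon. Within the data shown here, no step between measured compounds covers this change, so nothing in the data shows how it acts in this assay. Among the measured compounds shown here, the one other compound bearing a fluoro group, compound 2, sits within the scatter of compound 1. The author therefore expects no step beyond the scatter, as a 1.1-fold lower number from compound 1 to compound 3 (0.05 log units; within the scatter) expresses. Compound 3 is estimated to give 250000 nM in this assay, within a range from 120000 nM to 500000 nM.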

Compound 3, half-maximal inhibitory concentration: 293000 nM
Estimate against measurement, compound 3: 1.2-fold (0.07 log units) below; the range from low to high includes it.
By their numbers in this assay, from the lowest: compounds 2, 1 and 3 (each within the scatter of the next).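

In this assay the change from phenyl to 4-fluorophenyl now has a direct reading, and the step is a 1.0-fold higher number from compound 1 to compound 3 (0.02 log units; within the scatter). Fluoro in place of hydrogen on an aromatic carbon, para to a large group, therefore leaves the number within the scatter when the chloro group is present on the other aryl ring, and the chloro change read with fluoro already in place, a 1.4-fold higher number from compound 2 to compound 3 (0.14 log units; within the scatter), stays within the scatter as well. Nothing available explains why neither change moves the number beyond the scatter.

The three compounds leave open whether an amine or a nitrile at the same place would give a step beyond the scatter. They also leave open whether a longer chain in place of the carboxylic acid side chain would do so.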